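Replacing a pyrazolyl ring with a chloropyridyl ring

This account rests on a few compounds, and the source may have more. Where it says the series, first, only, none or still open, it means among the compounds named here.

Compound 1 `NC(=O)c1cn(-c2ccc(O)cc2C(F)(F)F)c2cc(-c3ccncc3)ccc2c1=O`: 20000 nM
Compound 2 `NC(=O)c1cn(-c2ccc(O)cc2Cl)c2cc(-n3cccn3)ccc2c1=O`: 600 nM

In an assay on isolated protein for inhibition of Calpain-1 catalytic subunit (Homo sapiens) (a higher number here means a weaker inhibitor, a lower number a stronger inhibitor), compound 2 gives the lowest number of the two, and compound 1 sits well beyond the scatter above it. Compound 3 `NC(=O)c1cn(-c2ccc(O)cc2Cl)c2cc(-c3ccncc3Cl)ccc2c1=O` differs from compound 2 by 3-chloropyridin-4-yl in place of 1H-pyrazol-1-yl on an aromatic carbon. Among the compounds with values here, no single-change step between the measured compounds is available, and compound 1 differs from compound 3 in two places, so the step is expected to be a weakening of moderate size a 5.0-fold higher number from compound 2 to compound 3 (0.70 log units; beyond the scatter). Compound 3 is estimated at 3000 nM, within 500 nM to 15000 nM.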

Compound 3, half-maximal inhibitory concentration: 2000 nM
Compound 3: the middle estimate sits 1.5-fold (0.18 log units) above what was measured; the measured number falls inside the stated range.
By their numbers in this assay, from the lowest: compound 2; then compound 3; then compound 1.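

At this aromatic carbon, this assay now gives a single-change reading: 3-chloropyridin-4-yl in place of 1H-pyrazol-1-yl produces a 3.3-fold higher number from compound 2 to compound 3 (0.52 log units; beyond the scatter), so the position responds to a change of ring, modestly and beyond the scatter. Nothing available explains this step. The comparison changes ring size, ring nitrogen count and chlorine together, so it remains open which of these differences accounts for the step. The compounds shown also leave open how an amine or a carboxylic acid on this aromatic carbon would read.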